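Hydroxy in Place of Propyl on the Shared Core

The compounds below may be only part of what the source reports. "The series", "measured", "known", "first", "only" and "open" are said of these compounds alone.

Within the data shown here, compound 1 `CCCCCc1cc2nn(-c3ccccc3)cc2c(C)n1` was tested in a functional assay on MCF7 cells (Homo sapiens) for inhibition, read by fluorescence, with a stated time of 72 h (on this read-out higher numbers stand for weaker inhibition of growth and lower numbers for stronger inhibition of growth), and gave 17000 nM, the larger of the two numbers measured so far, though the gap to the other is within the scatter. Compound 2 `c1ccc(-n2cc3cnc(-c4ccsc4)cc3n2)cc1` gave 9800 nM in this assay. Compound 3 `Cc1nc(CCO)cc2nn(-c3ccccc3)cc12` differs from compound 1 by hydroxy in place of propyl on a saturated chain carbon, two bonds along the chain from an aromatic carbon. Among the measured compounds shown here, no measured pair shows this change, so the step expected no change at the digits printed from compound 1 to compound 3 (within the scatter) is taken as nothing beyond the scatter, in either direction. Compound 3 is therefore expected to give 17000 nM in this assay, with a range from 5000 nM to 60000 nM.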

Compound 3, concentration for 50% growth inhibition: > 100000 nM
Compound 3 gave a limit, no number; the forecaster's own chance of this, stated with the estimate: 20%; middle value at least 5.8-fold (0.76 log units) away from the limit.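

In this assay, hydroxy in place of propyl on a saturated chain carbon, two bonds along the chain from an aromatic carbon, gives an at least 5.8-fold higher number from compound 1 to compound 3 (0.76 log units; beyond the scatter) as the first step read between compounds differing in one place. This shows that growth inhibition on the shared core is sensitive to this change. The reading for compound 3 is a limit and not a number, so the full size of the step stays unknown: the limit of > 100000 nM in this assay, at which 1 of the 3 values shown sits.

As far as these compounds go, whether an amine or a carboxylic acid at this place would read like hydroxy stays open, as does whether a longer chain ending in hydroxy would read like compound 1.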